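The source may report more compounds than this note shows. Statements on the series, on what has been measured and on what is new or still open speak of the compounds shown alone.

Measured so far:
compound 1, `COc1cc(-c2cc(/C=C/C(=O)c3ccc(N)cc3)[nH]n2)cc(OC)c1OC`: -91%
compound 2, `COc1ccc(-c2cc(/C=C/C(=O)c3ccc(OC)c(OC)c3)[nH]n2)cc1`: -66%
compound 3, `COc1cc(C(=O)/C=C/c2cc(-c3cc(OC)c(OC)c(OC)c3)n[nH]2)cc(OC)c1OC`: -99%

In a functional assay on OVCAR-8 cells (Homo sapiens) for cytotoxicity, read by sulforhodamine B assay, with a stated time of 48 h, tested at 100 uM (on this read-out higher numbers stand for a weaker effect at the one concentration tested and lower numbers for a stronger effect), compound 1 gives -91%. Compound 3 gives -99%, a number that lies within the usual scatter of the reading for compound 1, so the two cannot be told apart. Compound 2 gives -66%, a higher number beyond the scatter, so compound 2 shows a weaker effect at the concentration tested than compound 1 does. All three measured compounds still show strong effects at that concentration.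

Compound 4, `COc1cc(-c2cc(/C=C/C(=O)c3ccc(F)c(F)c3)[nH]n2)cc(OC)c1OC`, has not yet been measured. It differs from compound 1 in one place: 3,4-difluorophenyl in place of 4-aminophenyl on a carbonyl carbon. Going by the values given here, no measured pair differs in just this way, so the size of this step is not known from the data. With every measured compound already near the strong end of the read-out, the expected step is small, within the scatter, and a number 6 percentage points higher from compound 1 to compound 4 (within the scatter) is the expectation used here. Compound 4 is estimated at -85%, with a range from -100% to -55%.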

Compound 4, a percentage reported as activity, at one concentration (the size of the read-out at that concentration, not a potency): -12%
Compound 4: the middle estimate sits 73 percentage points below what was measured; the whole stated range lies below it.
By their numbers in this assay, from the lowest: compounds 3 and 1 (each within the scatter of the next); then compound 2; then compound 4.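

In this assay, going by these compounds alone, putting 3,4-difluorophenyl in place of 4-aminophenyl on the carbonyl carbon gives a number 79 percentage points higher from compound 1 to compound 4 (beyond the scatter), the first step that can be read at a single place. The earlier compounds shown here all sat near the strong end and no two differed in just one place, so they gave no sign that this group could matter so much; now it is clear that a six-membered aromatic ring of carbon at this place does not by itself preserve the effect. Nothing measured here explains the large step.

From the compounds shown here alone, it remains open whether losing the amine or adding the two fluorines drives the change. An unsubstituted phenyl or a 4-hydroxyphenyl group at the same place would help separate these two possibilities.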